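Amide substituent variation on the indole carboxamide series

The source may hold more compounds than are shown below. What is called first, only, known or untested is meant among the compounds shown, and "the series" means these compounds.

Of the compounds shown here, three of the shared core have been measured in a functional assay on MCF7 cells (Homo sapiens) for antiproliferative activity, read by CCK-8 assay, with a stated time of 72 h; on this read-out lower numbers stand for stronger inhibition of growth and higher numbers for weaker inhibition of growth. Compound 1 `CC[C@@H]1C(=O)N(C)c2cnc(Nc3ccc(S(=O)(=O)NCCO)cc3)nc2N1C1CCCC1` gives 344 nM. Compound 2 `CC[C@@H]1C(=O)N(C)c2cnc(-n3ccc4cc(C(=O)NC(C)C)ccc43)nc2N1C1CCCC1` gives 1670 nM, which places it between the other two: compound 1 stands lower, and compound 3 `CCC1C(=O)N(C)c2cnc(-n3ccc4cc(C(=O)NC(C)C)ccc43)nc2N1c1ccn(C)n1`, which gives 8420 nM, stands higher; both gaps are beyond the scatter of the assay. For the measured compounds named here, no pair of these three differs in only one place, so no single step can be read from them.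

Compound 4 `CC[C@@H]1C(=O)N(C)c2cnc(-n3ccc4cc(C(=O)NC5CCCC5)ccc43)nc2N1C1CCCC1` is not yet measured. It differs from compound 2 in one place, (cyclopentyl in place of isopropyl on an amide-type nitrogen), the difference being confined to the amide-type nitrogen of the isopropylcarbamoyl group. Going by the values given here, nothing among the measured compounds bears on this exchange, so the expectation rests on compound 2 alone. The step of a 1.3-fold lower number from compound 2 to compound 4 (0.11 log units; within the scatter) is expected to be small, with no direction beyond the scatter. In this assay compound 4 is therefore estimated at 1300 nM, within a range of 450 nM to 4000 nM.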

Compound 4, concentration for 50% growth inhibition: 795 nM
For compound 4 the middle estimate is 1.6-fold (0.21 log units) above the measured one; the range from low to high includes it.
By their numbers in this assay, from the lowest: compound 1; then compound 4; then compound 2; then compound 3.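

In this assay, cyclopentyl in place of isopropyl on the amide-type nitrogen gives a 2.1-fold lower number from compound 2 to compound 4 (0.32 log units; beyond the scatter). For the compounds shown here, this is the first exchange that can be read in one place, and it shows that the substituent on this amide-type nitrogen affects the number in this assay and that a ring of carbon only can stand there without loss of growth inhibition. No available measurement bears on what lies behind this step.

Still open, from the compounds shown here alone, is whether a cyclohexyl ring, a longer chain such as n-butyl, or an amine on the ring would move the number further in the same direction. Also open, going by these compounds, is whether the exchange has the same effect with the other substituents seen on the shared core, such as those of compound 3.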